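Shifting a methyl on the aryl tail of a chemokine receptor ligand

This account rests on a few compounds, and the source may have more. Where it says the series, first, only, none or still open, it means among the compounds named here.

Compound 1, `CC(C)CCC(=O)N[C@@H](C(=O)N1CCC(c2ccc(Cl)cc2)CC1)C(C)C`, gives 26 nM in an assay on THP-1 cells for displacement of a labelled ligand from C-C chemokine receptor type 1 (Homo sapiens); a higher number here means a weaker inhibitor, a lower number a stronger inhibitor.
Compound 2, `CC(C)[C@@H](NC(=O)CCCc1ccccc1)C(=O)N1CCC(c2ccc(Cl)cc2)CC1`, gives 95 nM in this assay.
Compound 3, `Cc1cccc(CCC(=O)N[C@@H](C(=O)N2CCC(c3ccc(Cl)cc3)CC2)C(C)C)c1`, gives 22 nM in this assay.

Compound 3 has the lowest of the three numbers. Its nearest neighbour is compound 1, and that pair lies within the scatter, as the step of a 1.2-fold lower number from compound 1 to compound 3 (0.07 log units; within the scatter) shows. The step of a 4.3-fold lower number from compound 2 to compound 3 (0.64 log units; beyond the scatter) is beyond the scatter, as is a 3.7-fold higher number from compound 1 to compound 2 (0.56 log units; beyond the scatter).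

Compound 4, `Cc1ccccc1CCC(=O)N[C@@H](C(=O)N1CCC(c2ccc(Cl)cc2)CC1)C(C)C`, differs from compound 3 only in the position of the methyl group on the aryl tail: 2-methylphenyl in place of 3-methylphenyl on a saturated chain carbon, two bonds along the chain from a carbonyl carbon. Within the data shown here, none of the measured steps moves a methyl around a ring; the steps that introduce the 3-methylphenyl group come from isopropyl or benzyl, and the move from isopropyl was within the scatter. A change that keeps the same atoms and only rearranges them on the ring is therefore expected to give a step of a 1.4-fold higher number from compound 3 to compound 4 (0.13 log units; within the scatter) that stays within the usual scatter, with no clear direction. Compound 4 is estimated to give 30 nM in this assay, with a range from 12 nM to 75 nM.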

Compound 4, half-maximal inhibitory concentration: 19 nM
Compound 4: middle estimate off by 1.6-fold (0.20 log units), on the high side; the range from low to high includes it.
By their numbers in this assay, from the lowest: compounds 4, 3 and 1 (each within the scatter of the next); then compound 2.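

In this assay, moving the methyl around the ring of the aryl tail gives a 1.2-fold lower number from compound 3 to compound 4 (0.06 log units; within the scatter), so this rearrangement of the same atoms, on a saturated chain carbon, two bonds along the chain from a carbonyl carbon, leaves the two tails indistinguishable. The 2-methylphenyl group also stays within the scatter of isopropyl, with a 1.4-fold lower number from compound 1 to compound 4 (0.14 log units; within the scatter), and like 3-methylphenyl it stands clear of benzyl, with a 5.0-fold lower number from compound 2 to compound 4 (0.70 log units; beyond the scatter). Nothing available explains why the methyl position makes so little difference here.

On these data alone, it remains open whether this tolerance extends beyond methyl, for instance to a methoxy group or a carboxylic acid in place of it on the ring. Also unresolved is how a longer chain between the carbonyl and the 2-methylphenyl ring would behave.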